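The compounds below may be only part of what the source reports. "The series", "measured", "known", "first", "only" and "open" are said of these compounds alone.

Compound 1 `CCC(CC)(c1ccc(OCC(O)C(C)(C)C)c(C)c1)c1ccc(C(=O)NCCCO)n1C`: 16400 nM
Compound 2 `CCn1c(C(=O)NCCO)ccc1C(CC)(CC)c1ccc(OCC(O)C(C)(C)C)c(C)c1`: 1810 nM

In a functional assay on MCF7 cells (Homo sapiens) for cytotoxicity, read by MTT assay, with a stated time of 48 h (on this read-out lower numbers stand for stronger inhibition and higher numbers for weaker inhibition), compound 2 at 1810 nM holds the lower of the two numbers, and compound 1 stands at 16400 nM. This gap lies beyond the scatter. Compound 3 `CCn1c(C(=O)N[C@@H](C)CO)ccc1C(CC)(CC)c1ccc(OCC(O)C(C)(C)C)c(C)c1` follows from compound 2 by methyl in place of hydrogen on a saturated chain carbon bound to an amide-type nitrogen and a saturated chain carbon. The two measured compounds differ in more than one place, so neither isolates this change. In this assay, no step beyond the scatter is expected. The estimated 1.0-fold lower number from compound 2 to compound 3 (0.00 log units; within the scatter) is small. For compound 3 the expected value is 1800 nM, with an estimated range of 650 nM to 5500 nM.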

Compound 3, half-maximal inhibitory concentration: 307 nM
For compound 3 the middle estimate is 5.9-fold (0.77 log units) above the measured one; measured number below the stated range.
By their numbers in this assay, from the lowest: compound 3; then compound 2; then compound 1.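

In this assay, methyl in place of hydrogen on the saturated chain carbon bound to an amide-type nitrogen and a saturated chain carbon gives a 5.9-fold lower number from compound 2 to compound 3 (0.77 log units; beyond the scatter) and so lowers the number beyond the scatter. For the compounds shown here, this is the first step that differs in one place, which lets this position be read on its own, unlike the gap between compound 1 and compound 2. No measurement shown accounts for the step.

Open, going by these compounds, is whether a longer chain such as ethyl at this carbon extends the step, and whether an amine in place of the hydroxyl keeps it.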